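Swapping a diol side chain for a diacid on the amide

The compounds below may be only part of what the source reports. "The series", "measured", "known", "first", "only" and "open" are said of these compounds alone.

Measured compounds:
Compound 1, `CCn1c(C(=O)NCCO)ccc1C(CC)(CC)c1ccc(OCS(=O)(=O)c2ccccc2)c(C)c1`, gives 15500 nM in a functional assay on MCF7 cells (Homo sapiens) for antiproliferative activity, read by MTT assay, with a stated time of 24 h; a lower number here means a stronger inhibitor, a higher number a weaker inhibitor.
Compound 2, `CCn1c(C(=O)N[C@H](C)CO)ccc1C(CC)(CC)c1ccc(OCS(=O)(=O)c2ccccc2)c(C)c1`, gives 10600 nM in this assay.
Compound 3, `CCn1c(C(=O)N[C@H](CO)CCO)ccc1C(CC)(CC)c1ccc(OCS(=O)(=O)c2ccccc2)c(C)c1`, gives 28500 nM in this assay.

All three share one core and differ only in the group carried on the amide nitrogen. Compound 3 has the highest number of the three: the step of a 1.8-fold higher number from compound 1 to compound 3 (0.26 log units; within the scatter) stays within the scatter, while the step of a 2.7-fold higher number from compound 2 to compound 3 (0.43 log units; beyond the scatter) is a modest change beyond it. The step of a 1.5-fold lower number from compound 1 to compound 2 (0.17 log units; within the scatter) also stays within the scatter.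

Compound 4, `CCn1c(C(=O)N[C@@H](CCC(=O)O)C(=O)O)ccc1C(CC)(CC)c1ccc(OCS(=O)(=O)c2ccccc2)c(C)c1`, has not yet been measured. Its change from compound 3 is 1,3-dicarboxypropyl in place of 3-hydroxy-1-(hydroxymethyl)propyl on an amide-type nitrogen. Both groups keep the same counts of hydrogen-bond donors and acceptors, but the entering group is larger and carries two carboxylic acids instead of two alcohols. Among the compounds with values here, no measured step involves an acid, so the only guidance is that side-chain changes so far moved the number little. Compound 4 is therefore expected to lie near compound 3, with a step of a 1.2-fold higher number from compound 3 to compound 4 (0.09 log units; within the scatter) that is not confidently beyond the scatter, though the range is wide. The estimate for compound 4 is 35000 nM, between 12000 nM and 100000 nM.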

Compound 4, half-maximal inhibitory concentration: > 50000 nM
Compound 4: no number, only a limit (the forecaster's own chance of this, stated with the estimate: 20%); middle value at least 1.4-fold (0.15 log units) away from the limit.
By their numbers in this assay, from the lowest: compounds 2, 1 and 3 (each within the scatter of the next, the first and the last beyond it). At a limit, above all of these: compound 4.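

Compound 4 gives no number in this assay, only a limit: the limit of > 50000 nM in this assay, at which 1 of the 4 values shown sits. Within the data shown here, with 1,3-dicarboxypropyl on the amide-type nitrogen, this position shows for the first time a change from the two smaller side chains that is beyond the scatter even at its floor: an at least 4.7-fold higher number from compound 2 to compound 4 (0.67 log units; beyond the scatter) and an at least 3.2-fold higher number from compound 1 to compound 4 (0.50 log units; beyond the scatter). The comparison with the diol side chain is less firm, since the reading is an at least 1.7-fold higher number from compound 3 to compound 4 (0.24 log units; that floor lies within the scatter), so swapping the two alcohols for two carboxylic acids brings no sign of stronger inhibition, but a true difference between these two compounds is not established.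

Going by these compounds, how far the true value of compound 4 lies past its limit stays open. Also open, on these data alone, is whether a side chain with a single carboxylic acid, or with an amine, would behave like the alcohols or like the diacid.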